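Turning One Stereocentre in a Weak Inhibitor

The source may report more compounds than this note shows. Statements on the series, on what has been measured and on what is new or still open speak of the compounds shown alone.

Of the compounds shown here, three sharing one core have been measured in a functional assay on B16-F10 cells (Mus musculus) for inhibition, read by colorimetric assay and MTT assay, with a stated time of 72 h; on this read-out higher numbers stand for weaker inhibition and lower numbers for stronger inhibition. Compound 1 `C/C1=C\CC[C@@]2(C)O[C@@H]2[C@H]2OC(=O)[C@@H](CN3CCCCC3)[C@@H]2C[C@H]1O`, which carries piperidin-1-yl, gives 4000 nM. Compound 2 `C/C1=C\CC[C@@]2(C)O[C@@H]2[C@H]2OC(=O)[C@@H](CN3CCN(C)CC3)[C@@H]2C[C@H]1O`, which carries 4-methylpiperazin-1-yl, gives 25000 nM, the highest number of the three and so the weakest inhibition. Compound 3 `C/C1=C\CC[C@@]2(C)O[C@@H]2[C@H]2OC(=O)[C@@H](CN3CCN(c4ccccc4F)CC3)[C@@H]2C[C@H]1O`, with 2-fluorophenyl in place of that methyl, gives 6000 nM.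

Compound 4 `C/C1=C\CC[C@@]2(C)O[C@@H]2[C@H]2OC(=O)[C@@H](CN3CCN(C)CC3)[C@@H]2C[C@@H]1O` has the same atoms and bonds as compound 2: the two compounds have the same atoms and bonds and differ only in configuration as drawn: 1 of 7 stereo elements differ; a stereocentre at a saturated ring carbon is drawn R in compound 2 and S in compound 4. A stereocentre at a saturated ring carbon is drawn R in compound 2 and S in compound 4.

The measured steps are a 6.3-fold higher number from compound 1 to compound 2 (0.80 log units; beyond the scatter) and a 4.2-fold lower number from compound 2 to compound 3 (0.62 log units; beyond the scatter). Both exchange a group and leave the configuration alone, so they bear on this change only indirectly, showing how far single changes have moved the number among these three compounds. Among the measured compounds shown here, no measured pair shows what a change of configuration does, and the direction remains open. Compound 2 already stands highest, so a slight drop is a little more likely than a rise, but no step beyond the scatter is expected. The expected step is a 1.3-fold lower number from compound 2 to compound 4 (0.10 log units; within the scatter). For compound 4 the estimated value is 20000 nM, with an expected range of 7000 nM to 60000 nM.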

Compound 4, half-maximal inhibitory concentration: 9000 nM
Compound 4: middle estimate off by 2.2-fold (0.35 log units), on the high side, and the stated range covers the measured number.
By their numbers in this assay, from the lowest: compounds 1, 3 and 4 (each within the scatter of the next, the first and the last beyond it); then compound 2.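

Until now every measured step exchanged a group, which left the role of configuration at this carbon unknown. In this assay, changing a saturated ring carbon from R to S while keeping the 4-methylpiperazin-1-yl group brings a 2.8-fold lower number from compound 2 to compound 4 (0.44 log units; beyond the scatter) and settles the direction for this pair, with S giving the stronger inhibition. The shift can be assigned to the stereocentre alone, with no exchange of groups to share in it, because of one plain fact: the fact that compounds 2 and 4 differ only in the configuration as drawn.

This carbon is therefore a place where the drawn configuration by itself moves the number, although that conclusion rests on this single pair. Whether S lowers the number in the same way with piperidin-1-yl or with 2-fluorophenyl on the piperazine stays open, as does the effect of this change with another amine such as morpholin-4-yl, and the compounds shown say nothing about turning any of the remaining stereo elements.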